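Hexafluoro-carbinol phenols: the benzyl amide variant

The compounds below may be only part of what the source reports. "The series", "measured", "known", "first", "only" and "open" are said of these compounds alone.

Of the compounds shown here, three have been measured in an assay on isolated protein for inhibition of receptor-type tyrosine-protein phosphatase C (Homo sapiens), read by spectrophotometry (a higher number here means a weaker inhibitor, a lower number a stronger inhibitor), so far. Compound 1 `Oc1ccc(-c2ccccc2)cc1C(O)(C(F)(F)F)C(F)(F)F` returns only a limit, > 500000 nM. Compound 3 `Oc1c(C(O)(C(F)(F)F)C(F)(F)F)ccc2ccccc12` likewise returns only a limit, > 500000 nM. Compound 2 `COc1ccc(CNC(=O)COc2ccc3cc(C(O)(C(F)(F)F)C(F)(F)F)c(O)cc3c2)cc1OC` also returns only a limit, in this case > 20000 nM. Thus all three values are limits, two sitting at the limit of > 500000 nM in this assay, at which 2 of the 3 values shown sit, and one at the limit of > 20000 nM in this assay, at which 1 of the 3 values shown sits, and no finished number exists in the series.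

Compound 4 `O=C(COc1ccc2cc(C(O)(C(F)(F)F)C(F)(F)F)c(O)cc2c1)NCc1ccccc1` carries the change (phenyl in place of 3,4-dimethoxyphenyl on a saturated chain carbon bound to an amide-type nitrogen). Going by the values given here, with no measured step to lean on, the expectation is a change no larger than the usual scatter, and a limit is again the likeliest outcome. The estimated step in this assay is a step that the limit leaves unreadable from compound 2 to compound 4. Compound 4 is accordingly expected near 30000 nM, within 10000 nM to 200000 nM.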

Compound 4, half-maximal inhibitory concentration: > 20000 nM
Compound 4 was reported as a limit (the forecaster's own chance of this, stated with the estimate: 75%); the middle value does not contradict the limit.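

In this assay compound 4 gives only a limit, > 20000 nM. Compound 2 also gives only a limit, > 20000 nM, and no step can be read between compound 2 and compound 4. The compounds shown leave open whether any member of this series gives a finished number.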